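A few compounds are considered here, and "the series" means these few. Any claim that something is new, unique, unknown or untested is made for them only; others in the source may bear on it.

Measured so far:
compound 1 `Nc1ccccc1NC(=O)c1ccc(CNC2=N[C@@H](c3ccccc3)CN2)cc1`, 78%
compound 2 `Nc1ccccc1NC(=O)c1ccc(CSC2=N[C@@H](Cc3ccccc3)CO2)cc1`, 60%

In an assay on isolated protein for inhibition of protein deacetylase HDAC6 (Homo sapiens), read by fluorescence, with a stated time of 1 h, tested at 20 uM (a higher number here means more inhibition at the concentration tested (going by the name of the read-out), a lower number less inhibition), compound 1 gives 78%, and compound 2 gives 60%, the lower of the two numbers, with compound 1 beyond the scatter above it. Compound 3 `Nc1ccccc1NC(=O)c1ccc(CSC2=N[C@@H](c3cccnc3)CO2)cc1` differs from compound 2 in one place: pyridin-3-yl in place of benzyl on a saturated ring carbon, on a saturated ring carbon of the five-membered non-aromatic ring. Among the compounds with values here, no measured pair shows this change, so the direction is open. The step from compound 2 to compound 3 is expected to be a number 5 percentage points lower from compound 2 to compound 3 (within the scatter), small, and not clearly beyond the scatter. Compound 3 is estimated to give 55% in this assay, within 35% to 75%.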

Compound 3, a percentage reported as inhibition, at one concentration (the size of the read-out at that concentration, not a potency) in the protein deacetylase HDAC6 assay: 62%
Compound 3: the middle estimate sits 7 percentage points below what was measured; measured number inside the range.
By their numbers in the protein deacetylase HDAC6 assay, from the lowest: compounds 2 and 3 (each within the scatter of the next); then compound 1.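

In the protein deacetylase HDAC6 assay, pyridin-3-yl in place of benzyl on this saturated ring carbon, next to the ring nitrogen, gives a number 2 percentage points higher from compound 2 to compound 3 (within the scatter), so the two compounds cannot be told apart here. The same swap separates them clearly in a physicochemical assay for lipophilicity, read by HPLC (on this read-out higher numbers stand for higher lipophilicity and lower numbers for lower lipophilicity), where compound 2 gives 5.41 and compound 3 gives 3.19: the measured distribution coefficient of compound 2, 5.41, and of compound 3, 3.19, a number 2.22 log units lower (beyond the scatter). For this pair, the inhibition read at a single concentration thus does not follow a large step in the distribution coefficient.

Going by these compounds, whether an amine or a carboxylic acid on this ring carbon would give a similar reading stays open. These percentages also leave the potency of compound 2 and compound 3 open.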